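Amide ring swap in a weakly antiproliferative series

This account rests on a few compounds, and the source may have more. Where it says the series, first, only, none or still open, it means among the compounds named here.

Compound 1 `O=C(Nc1ccc(Cl)c(-c2nnc3c(Cl)cccn23)c1)c1cccc(Cl)c1`: 30200 nM
Compound 2 `O=C(Nc1ccc(Cl)c(-c2nnc3c(Cl)cccn23)c1)c1cccnc1Cl`: a limit of the assay, > 100000 nM

In a functional assay on T47D cells (Homo sapiens) for antiproliferative activity, read by MTT assay, with a stated time of 72 h (a lower number here means a stronger inhibitor, a higher number a weaker inhibitor), compound 1 gives 30200 nM. Compound 2 reaches only a limit of this assay, > 100000 nM. Compound 2 therefore stands at the weaker end of the two values shown, and the step of an at least 3.3-fold higher number from compound 1 to compound 2 (0.51 log units; beyond the scatter) is bounded in size only by the limit of > 100000 nM in this assay, at which 1 of the 2 values shown sits.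

Compound 3 `O=C(Nc1ccc(Cl)c(-c2nnc3c(Cl)cccn23)c1)c1ccccc1` differs from compound 2 by phenyl in place of 2-chloropyridin-3-yl on a carbonyl carbon. Within the data shown here, the one measured step that bears on this change is an at least 3.3-fold higher number from compound 1 to compound 2 (0.51 log units; beyond the scatter), which rose when the chlorophenyl amide gave way to the chloropyridinyl amide. Removing the pyridinyl ring again is expected to move this assay back down, roughly undoing that rise. Compound 3 is thus expected to give about 40000 nM, between 15000 nM and 100000 nM. The expected step is an at least 2.5-fold lower number from compound 2 to compound 3 (0.39 log units; beyond the scatter).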

Compound 3, half-maximal inhibitory concentration: > 100000 nM
Compound 3 was reported as a limit (the forecaster's own chance of this, stated with the estimate: 35%); at least 2.5-fold (0.39 log units) between middle value and limit.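

In this assay compound 3 gives > 100000 nM, which is a limit of the assay. Hydrogen in place of chloro on an aromatic carbon is enough on its own to give an at least 3.3-fold higher number from compound 1 to compound 3 (0.51 log units; beyond the scatter), so the weakening seen earlier does not require the ring nitrogen of the 2-chloropyridin-3-yl group, and the chloro of the 3-chlorophenyl amide counts for this read-out. The steps between compound 2 and compound 3 cannot be read, and the two cannot be ordered, as the series now rests largely on one boundary: the limit of > 100000 nM in this assay, at which 2 of the 3 values shown sit.

As far as these compounds go, whether a bromo, methoxy or amine group in place of that chloro would hold or strengthen the activity of compound 1 remains open. From the compounds shown here alone, how far compound 2 and compound 3 actually lie beyond the limit also remains open.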